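Swapping Fluoro for Chloro in a Weak Growth Inhibitor

The source may hold more compounds than are shown below. What is called first, only, known or untested is meant among the compounds shown, and "the series" means these compounds.

- Compound 1 `CCOC(=O)c1nn(-c2ccc(Cl)cc2)c(-c2ccc(Cl)cc2)c1CNC(C)(C)C` gives 196000 nM; > 519000 nM (2 entries)
- Compound 2 `CC(C)(C)NCc1c(C(=O)O)nn(-c2ccc(Cl)cc2)c1-c1ccc(F)cc1` gives > 623000 nM

Both compounds were tested in a functional assay on PC-3 cells (Homo sapiens) for inhibition, read by sulforhodamine B assay, with a stated time of 48 h; on this read-out higher numbers stand for weaker inhibition of growth and lower numbers for stronger inhibition of growth. Compound 2 has no single number here, and its value of > 623000 nM is a limit of the assay. Compound 3 `CC(C)(C)NCc1c(C(=O)O)nn(-c2ccc(Cl)cc2)c1-c1ccc(Cl)cc1` has not yet been measured. It carries chloro in place of fluoro on an aromatic carbon, so 4-fluorophenyl becomes 4-chlorophenyl (chloro in place of fluoro on an aromatic carbon). Within the data shown here, no measured pair shows this exchange on its own, so the data give no direct size for it. The expectation in this assay is therefore no change beyond the usual scatter, with no favoured direction. The expected step is an at least 1.1-fold lower number from compound 2 to compound 3 (0.05 log units; that floor lies within the scatter). A limit rather than a number is the likely report for compound 3. The estimate for compound 3 is 550000 nM, with an expected range from 200000 nM to 800000 nM.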

Compound 3, concentration for 50% growth inhibition: > 599000 nM
Compound 3 ended at the assay's limit; the forecaster's own chance of this, stated with the estimate: 75%; middle value at least 1.0-fold (0.03 log units) away from the limit.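

Among these compounds, compound 2 and compound 3 each gave only a limit rather than a number, so no step between them can be read. The compounds shown leave open whether going from 4-fluorophenyl to 4-chlorophenyl shifts growth inhibition at all, and in which direction.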